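A second fluorine on compound 3

The compounds below may be only part of what the source reports. "The series", "measured", "known", "first", "only" and "open" are said of these compounds alone.

In an ADME assay on TZM cells (Homo sapiens) for cytotoxicity, read by CCK-8 assay, with a stated time of 2 days (on this read-out lower numbers stand for higher toxicity in this test and higher numbers for lower toxicity in this test), compound 3 (`O=C(Nc1ccc(CCS(=O)(=O)/C=C/c2ccc(O)c(O)c2)cc1)c1ccc(F)cc1`) gives > 1000000 nM, which is a limit of the assay and not a number. Compound 2 (`COc1ccc(C(=O)Nc2ccc(CCS(=O)(=O)/C=C/c3ccc(O)c(O)c3)cc2)cc1`) gives > 1000000 nM, which is also a limit. Compound 3 thus stands at the limit of > 1000000 nM in this assay, at which 2 of the 3 values shown sit. Only compound 1 (`O=C(Nc1ccc(CCS(=O)(=O)/C=C/c2ccc(O)c(O)c2)cc1)c1ccccc1`) gives a number, 238000 nM.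

Compound 4 (`O=C(Nc1ccc(CCS(=O)(=O)/C=C/c2ccc(O)c(O)c2)cc1)c1cc(F)cc(F)c1`) has 3,5-difluorophenyl in place of 4-fluorophenyl on a carbonyl carbon.

The closest guide is the step of an at least 4.2-fold higher number from compound 1 to compound 3 (0.62 log units; beyond the scatter), which put fluoro in place of hydrogen on an aromatic carbon. The step of an at least 4.2-fold higher number from compound 1 to compound 2 (0.62 log units; beyond the scatter), with methoxy in place of hydrogen, ran the same way, while the step that the two limits leave unreadable from compound 2 to compound 3 adds nothing. For the measured compounds named here, no measured step exchanges one fluorinated ring for another. With the step of an at least 4.2-fold higher number from compound 1 to compound 3 (0.62 log units; beyond the scatter) as a guide, this assay is expected to show no fall beyond the scatter, and another limit is likely. The estimated step is a number no higher from compound 3 to compound 4 (the limit leaves the size open). Compound 4 is expected near 1000000 nM, with an estimated range from 300000 nM to 2000000 nM.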

Compound 4, half-maximal cytotoxic concentration: 414000 nM
Estimate against measurement, compound 4: 2.4-fold (0.38 log units) above; the range from low to high includes it.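

In this assay, the ring on the carbonyl carbon can also move the read-out downward: 3,5-difluorophenyl in place of 4-fluorophenyl gives an at least 2.4-fold lower number from compound 3 to compound 4 (0.38 log units; beyond the scatter), and in place of 4-methoxyphenyl it gives an at least 2.4-fold lower number from compound 2 to compound 4 (0.38 log units; beyond the scatter). Fluorine on this ring therefore does not by itself keep a compound at the limit, and a 1.7-fold higher number from compound 1 to compound 4 (0.24 log units; within the scatter) leaves the difluorinated compound and the unsubstituted phenyl compound apart by no readable margin. The true size of the first two steps stays open, since compound 2 and compound 3 each give a limit and not a number: the limit of > 1000000 nM in this assay, at which 2 of the 4 values shown sit.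

The compounds shown leave open whether the fall follows the number of fluorines or their placement, as this one change alters both. They also leave open how an amine or a carboxylic acid on this ring would read in this assay.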